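Taking the Trifluoromethyl Group off Compound 1

A few compounds are considered here, and "the series" means these few. Any claim that something is new, unique, unknown or untested is made for them only; others in the source may bear on it.

Of the compounds shown here, three built on a shared core have been tested in a functional assay on HepG2 cells (Homo sapiens) for inhibition, read by MTT assay, with a stated time of 48 h (a higher number here means a weaker inhibitor, a lower number a stronger inhibitor), so far. Going by the values given here, compound 1 (`Fc1ccc(/C=N/Nc2nc(-c3ccc(C(F)(F)F)cc3)cs2)cc1F`) gives 14500 nM in this test, one of only two actual numbers. The other number belongs to compound 3 (`COc1cc(/C=N/Nc2nc(-c3ccc(F)c(F)c3)cs2)cc(Br)c1OC`), which gives 22400 nM here. These two lie within the usual scatter of each other, so neither can be called the stronger inhibitor. Compound 2 (`COc1cc(/C=N/Nc2nc(-c3ccc(C(F)(F)F)cc3)cs2)c(Br)c(Br)c1OC`) gives > 100000 nM in this assay and this is a limit, not a number.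

The next compound to be tested is compound 4 (`Fc1ccc(/C=N/Nc2nc(-c3ccccc3)cs2)cc1F`). It is compound 1 with hydrogen in place of trifluoromethyl on an aromatic carbon. Among the compounds with values here, no tested pair shows this change alone, so there is no direct guide to its size. The closest hint is compound 3, which also has no trifluoromethyl and still gives 22400 nM as a real number, although it differs from compound 1 in other places too. On that basis, only a small shift toward a weaker inhibitor is expected, possibly none beyond the scatter. The expected step is a 1.7-fold higher number from compound 1 to compound 4 (0.22 log units; within the scatter) in this assay as an estimate. Compound 4 is estimated at 24000 nM with a likely range from 8000 nM to 70000 nM in this test.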

Compound 4, half-maximal inhibitory concentration: > 100000 nM
Compound 4 was reported as a limit; the forecaster's own chance of this, stated with the estimate: 15%; middle value at least 4.1-fold (0.61 log units) from the limit.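

Trifluoromethyl at this place on compound 1 clearly counts in this assay: putting hydrogen in its place gives an at least 6.8-fold higher number from compound 1 to compound 4 (0.83 log units; beyond the scatter), and this is a change large enough to stand out from ordinary repeat-to-repeat variation. Going by these compounds alone, none of the earlier compounds could show this, as no tested pair differed at this position alone, so this is the first clean reading of what the group contributes to the measured inhibition. Going by these compounds, compound 4 gives > 100000 nM, which is a limit and not a number, so the step marks only a minimum size and its full extent stays unknown, and this same limit is common in so small a set: the limit of > 100000 nM in this assay, at which 2 of the 4 values shown sit.

The compounds shown leave open whether trifluoromethyl itself is required at this place, or whether a smaller or quite different group, such as a chlorine atom, an amine or a carboxylic acid, would keep compound 1 measurable. They also leave open whether swapping trifluoromethyl for hydrogen would have a similar effect with other substituents elsewhere on the shared core.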